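A few compounds are considered here, and "the series" means these few. Any claim that something is new, unique, unknown or untested is made for them only; others in the source may bear on it.

Going by the values given here, in a functional assay on SK-OV-3 cells (Homo sapiens) for antiproliferative activity, read by MTT assay (a lower number here means a stronger inhibitor, a higher number a weaker inhibitor), compound 2 `CCCCOC(=O)N1CCCc2cc(S(=O)(=O)N3CC(c4ccccc4)NC3=O)ccc21` gives 9570 nM, one of only two numbers measured so far; compound 1 `CC(C)COC(=O)N1CCCc2cc(S(=O)(=O)N3CC(c4ccccc4)NC3=O)ccc21` gives 5650 nM, and the step of a 1.7-fold higher number from compound 1 to compound 2 (0.23 log units; within the scatter) lies within the scatter. Compound 3 `O=C(NC1CCCCC1)N1CCCc2cc(S(=O)(=O)N3CC(c4ccccc4)NC3=O)ccc21` differs from compound 2 in a single place: cyclohexylamino in place of butoxy on a carbonyl carbon. Among the compounds with values here, the one measured step swaps propyl for isopropyl and leaves the carbonyl group untouched, so it bears only loosely on this change and gives no direction. The step of a 1.2-fold lower number from compound 2 to compound 3 (0.08 log units; within the scatter) is therefore expected to stay small. Compound 3 is estimated at 8000 nM, with a range from 2000 nM to 30000 nM.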

Compound 3, half-maximal inhibitory concentration: 1840 nM
The estimate for compound 3 lay 4.3-fold (0.64 log units) above the measured number; measured number outside the range, below it.
By their numbers in this assay, from the lowest: compound 3; then compounds 1 and 2 (each within the scatter of the next).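

In this assay the group on the carbonyl carbon can shift the number beyond the scatter, which the earlier swap of one chain for another did not do. Cyclohexylamino in place of butoxy gives a 5.2-fold lower number from compound 2 to compound 3 (0.72 log units; beyond the scatter) and cyclohexylamino in place of isobutoxy gives a 3.1-fold lower number from compound 1 to compound 3 (0.49 log units; beyond the scatter) with the rest of the molecule unchanged. Nothing available explains this shift.

Going by these compounds, the change brings in a ring and an amide hydrogen together, so their shares stay open. A butylamino or a cyclohexyloxy group on the same carbonyl carbon would separate them.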